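Anilide variation on a shared core: toward compound 4

The source may report more compounds than this note shows. Statements on the series, on what has been measured and on what is new or still open speak of the compounds shown alone.

Measured compounds:
- compound 1, `O=C(CSc1nc(Nc2ccccc2)c2ccccc2n1)Nc1cccc(F)c1`, in a functional assay on PC-3 cells (Homo sapiens) for inhibition, read by MTT assay, with a stated time of 72 h (on this read-out lower numbers stand for stronger inhibition and higher numbers for weaker inhibition), compound 1 gives 15600 nM
- compound 2, `O=C(CSc1nc(Nc2ccccc2)c2ccccc2n1)Nc1cccc([N+](=O)[O-])c1`, compound 2 gives 11800 nM
- compound 3, `O=C(CSc1nc(Nc2ccccc2)c2ccccc2n1)Nc1ccc(Cl)cc1`, compound 3 gives 12900 nM

All three share one core and differ only in the anilide aryl. Compound 3 sits second highest of the three numbers; its nearest neighbour is compound 2 with a 1.1-fold higher number from compound 2 to compound 3 (0.04 log units; within the scatter), its furthest is compound 1 with a 1.2-fold lower number from compound 1 to compound 3 (0.08 log units; within the scatter). The remaining step, a 1.3-fold lower number from compound 1 to compound 2 (0.12 log units; within the scatter), is also within the scatter. So far no change on the anilide aryl has moved the read-out beyond noise.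

Compound 4, `O=C(CSc1nc(Nc2ccccc2)c2ccccc2n1)Nc1ccc(Cl)c(Cl)c1`, extends this line. Relative to compound 3 the change is chloro in place of hydrogen on an aromatic carbon; the new chloro sits on an aromatic carbon of a six-membered aromatic ring of carbon only, ortho to a chloro group and meta to a large group, so that 4-chlorophenyl becomes 3,4-dichlorophenyl. Among the measured compounds shown here, no measured step adds a second substituent to this ring, but the three steps that do touch it are all within the scatter, and a step of comparable size, in either direction, is the natural expectation in this assay.

The expected step is a 1.3-fold lower number from compound 3 to compound 4 (0.11 log units; within the scatter), with a slightly lower number favoured. Compound 4 is therefore estimated at 10000 nM, within 5000 nM to 22000 nM.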

Compound 4, half-maximal inhibitory concentration: 12100 nM
Compound 4: middle estimate off by 1.2-fold (0.08 log units), on the low side; measured number inside the range.
By their numbers in this assay, from the lowest: compounds 2, 4, 3 and 1 (each within the scatter of the next).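

In this assay, adding a further chloro on an aromatic carbon, ortho to a chloro group and meta to a large group, gives a 1.1-fold lower number from compound 3 to compound 4 (0.03 log units; within the scatter); this is the first step shown that adds a substituent to the anilide ring rather than exchanging one, and it stays within the scatter. The 3,4-dichlorophenyl anilide also stays within the scatter of the two other aryl groups, with a 1.0-fold higher number from compound 2 to compound 4 (0.01 log units; within the scatter) and a 1.3-fold lower number from compound 1 to compound 4 (0.11 log units; within the scatter), so in this set of four compounds a ring carrying two chloro groups cannot be told apart from a ring carrying one fluoro, nitro or chloro group. No measurement is at hand that would explain this flat read-out.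

Going by these compounds, whether an amine, a carboxylic acid or a methoxy group on the anilide ring would move the number beyond the scatter remains open. Also open, on these data alone, is whether a change away from the anilide, such as a hydroxyl or a longer chain on the phenylamino group of the shared core, would move the read-out at all.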